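The compounds below may be only part of what the source reports. "The series", "measured", "known", "first", "only" and "open" are said of these compounds alone.

Measured so far:
- Compound 1, `COc1cc(-c2cc(/C=C/C(=O)c3ccc(N)cc3)[nH]n2)cc(OC)c1OC`: -94% in a functional assay on SNB-19 cells (Homo sapiens) for cytotoxicity, read by sulforhodamine B assay, with a stated time of 48 h, tested at 100 uM; a higher number here means a weaker effect of the compound at the concentration tested, a lower number a stronger effect
- Compound 2, `COc1ccc(-c2cc(/C=C/C(=O)c3ccc(N)cc3)[nH]n2)cc1OC`: -91% in this assay

Compound 1 gives the lower of the two numbers, but the step of a number 3 percentage points higher from compound 1 to compound 2 (within the scatter) is within the scatter, so the two compounds cannot be ordered. Compound 3, `COc1cc(-c2cc(/C=C/C(=O)c3ccc(F)c(F)c3)[nH]n2)cc(OC)c1OC`, has not been measured. It differs from compound 1 in one place: 3,4-difluorophenyl in place of 4-aminophenyl on a carbonyl carbon. For the measured compounds named here, the single measured step, from compound 1 to compound 2, changes the other aromatic ring and leaves the 4-aminophenyl untouched, so no measured step bears on this change. Both measured compounds sit at strongly negative values, and compound 3 is expected to stay in that region, with the step of a number 19 percentage points higher from compound 1 to compound 3 (beyond the scatter) allowing for some loss. For compound 3 the estimate is -75%, ranging from -100% to -30%.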

Compound 3, a percentage reported as activity, at one concentration (the size of the read-out at that concentration, not a potency): 22%
Estimate against measurement, compound 3: 97 percentage points below; measured number outside the range, above it.
By their numbers in this assay, from the lowest: compounds 1 and 2 (each within the scatter of the next); then compound 3.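

At the carbonyl carbon, the aromatic group matters a great deal: putting 3,4-difluorophenyl in place of 4-aminophenyl gives a number 116 percentage points higher from compound 1 to compound 3 (beyond the scatter) in this assay, a large loss of effect. This single change is enough to weaken the compound sharply while the rest of the structure stays the same. Nothing measured here explains why this happens.

Still open, as far as these compounds go, is whether the loss comes from removing the amino group or from adding the two fluorines. A plain phenyl or a 4-hydroxyphenyl at this carbon would help separate these possibilities.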